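A few compounds are considered here, and "the series" means these few. Any claim that something is new, unique, unknown or untested is made for them only; others in the source may bear on it.

Working notes on the series. Among the compounds with values here, in a functional assay on HeLa cells (Homo sapiens) for cytotoxicity, read by MTT assay (a lower number here means a stronger inhibitor, a higher number a weaker inhibitor), compound 1 (`CCCC(O)CC(=O)O[C@H](CC=C(C)C)C1=CC(=O)c2c(O)ccc(O)c2C1=O`) gives 59300 nM and compound 2 (`CC(C)=CC[C@@H](OCC(C)O)C1=CC(=O)c2c(O)ccc(O)c2C1=O`) gives 24700 nM as the lower of the two numbers so far. Compound 3 (`CC(=O)OC(C)CO[C@H](CC=C(C)C)C1=CC(=O)c2c(O)ccc(O)c2C1=O`) has acetyl in place of hydrogen on an oxygen on a saturated carbon so that 2-hydroxypropyl becomes 2-acetoxypropyl. Within the data shown here, only one measured step is available (a 2.4-fold lower number from compound 1 to compound 2 (0.38 log units; beyond the scatter)) and it bears on this change only loosely, since it exchanges a different pair of groups. Among the measured compounds shown here, no measurement yet shows what acetyl does here. For the measured compounds named here, with that single modest step as the only guide, a step of no more than similar size is expected in this assay and no firm direction can be set. The estimated step (a 1.1-fold lower number from compound 2 to compound 3 (0.05 log units; within the scatter)) is expected to stay within the scatter. In this assay the estimate for compound 3 is 22000 nM (expected range 9000 nM to 55000 nM).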

Compound 3, half-maximal inhibitory concentration: 40100 nM
Beside the measured number, compound 3's estimate is 1.8-fold (0.26 log units) below it; measured number inside the range.
By their numbers in this assay, from the lowest: compounds 2, 3 and 1 (each within the scatter of the next, the first and the last beyond it).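

In this assay, acetyl on the oxygen of 2-hydroxypropyl gives a 1.6-fold higher number from compound 2 to compound 3 (0.21 log units; within the scatter) and so shows that, at this oxygen on a saturated carbon, hydrogen can give way to acetyl without a step beyond the scatter. Placing 2-acetoxypropyl where (2-hydroxypentyl)carbonyl stands gives a 1.5-fold lower number from compound 1 to compound 3 (0.17 log units; within the scatter) and so compound 3 cannot be told apart from compound 1 or compound 2, although those two lie beyond the scatter of each other. Nothing on hand offers a reason for either step.

As far as these compounds go, whether a longer acyl chain or an amine on this oxygen would produce a step beyond the scatter remains open. Also open, from the compounds shown here alone, is whether acetyl on the hydroxy of the (2-hydroxypentyl)carbonyl group would give a similarly small step.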